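A few compounds are considered here, and "the series" means these few. Any claim that something is new, unique, unknown or untested is made for them only; others in the source may bear on it.

In a functional assay on LoVo cells (Homo sapiens) for inhibition, read by MTT assay, with a stated time of 48 h (on this read-out higher numbers stand for weaker inhibition and lower numbers for stronger inhibition), compound 1 (`C[Se]c1ccc(N(C)c2nc(C3CC3)nc3ccccc23)cc1`) gives 11 nM, compound 2 (`COc1ccc(N(C)c2nc(C)nc3ccccc23)cc1C(=O)OCC[Se]C#N`) gives 2960 nM, and compound 3 (`COc1ccc(N(C)c2nc(C)nc3ccccc23)cc1C(=O)NCC[Se]C#N`) gives 561 nM, the second highest of these three numbers. Compound 4 (`COc1ccc(N(C)c2nc(C)nc3ccccc23)cc1C[Se]C#N`) has not yet been measured. Its change from compound 3 is a group of 4 heavy atoms (2 carbon, 1 nitrogen, 1 selenium; no ring) in place of a group of 8 heavy atoms (4 carbon, 2 nitrogen, 1 oxygen, 1 selenium; no ring), on an aromatic carbon. Among the measured compounds shown here, the one measured step in this part of the molecule is a 5.3-fold lower number from compound 2 to compound 3 (0.72 log units; beyond the scatter), which is modest, but it leaves the chain in place. Compound 1, which lacks this chain, reaches 11 nM, although it also differs elsewhere, so it is only a loose guide. A modest step towards stronger inhibition is therefore expected, a 3.7-fold lower number from compound 3 to compound 4 (0.57 log units; beyond the scatter). The estimated value for compound 4 is 150 nM, with an expected range from 30 nM to 700 nM.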

Compound 4, half-maximal inhibitory concentration: 277 nM
The estimate for compound 4 lay 1.8-fold (0.27 log units) below the measured number; measured number inside the range.
By their numbers in this assay, from the lowest: compound 1; then compound 4; then compound 3; then compound 2.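

In this assay cutting the chain on this aromatic carbon down to 4 heavy atoms, with no carbonyl and no hydrogen-bond donor left, gives a 2.0-fold lower number from compound 3 to compound 4 (0.31 log units; beyond the scatter) and so does not cost inhibition. Set against the ester chain, the same short group gives an 11-fold lower number from compound 2 to compound 4 (1.03 log units; beyond the scatter) and shows that a carbonyl in the chain is not required for inhibition in these cells. No measurement here bears on why these steps occur. Going by these compounds, whether a group without selenium, such as a plain methyl or an amine, would keep this inhibition stays open. So does the effect of a carboxylic acid on this carbon.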